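Chloro for trifluoromethyl: from compound 3 to compound 4

This account rests on a few compounds, and the source may have more. Where it says the series, first, only, none or still open, it means among the compounds named here.

Values in an ADME assay on BHK-21 cells (Mesocricetus auratus) for cytotoxicity, read by MTT assay, with a stated time of 72 h; on this read-out lower numbers stand for higher toxicity in this test and higher numbers for lower toxicity in this test:
compound 1 `Cc1ccc(NCc2cn(-c3ccccc3)nc2-c2ccc(Cl)cc2)cc1`: > 100000 nM, a limit of the assay
compound 2 `Cc1ccc(NCc2cn(-c3ccccc3)nc2-c2ccc(C(F)(F)F)cc2)cc1`: 88000 nM
compound 3 `FC(F)(F)c1ccc(NCc2cn(-c3ccccc3)nc2-c2ccc(C(F)(F)F)cc2)cc1`: 27000 nM

Going by the values given here, compound 3 holds the lowest actual number so far, reached by a 3.3-fold lower number from compound 2 to compound 3 (0.51 log units; beyond the scatter). Compound 4 `FC(F)(F)c1ccc(NCc2cn(-c3ccccc3)nc2-c2ccc(Cl)cc2)cc1` changes one group of compound 3: chloro in place of trifluoromethyl on an aromatic carbon. In words, this is chloro in place of trifluoromethyl on an aromatic carbon. The closest measured change is the same swap in reverse, an at least 1.1-fold lower number from compound 1 to compound 2 (0.05 log units; that floor lies within the scatter), and it suggests a small rise in this assay, perhaps none beyond the scatter. As far as these compounds go, for compound 1 the true size of that step stays open because of the limit of > 100000 nM in this assay, at which 1 of the 3 values shown sits. The estimated step is a 1.3-fold higher number from compound 3 to compound 4 (0.12 log units; within the scatter). For compound 4 the expected value is 36000 nM, with an estimated range of 20000 nM to 70000 nM.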

Compound 4, half-maximal cytotoxic concentration: 17000 nM
Beside the measured number, compound 4's estimate is 2.1-fold (0.33 log units) above it; the whole stated range lies above it.
By their numbers in this assay, from the lowest: compounds 4 and 3 (each within the scatter of the next); then compound 2. At a limit, above all of these: compound 1.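

In this assay the change from 4-(trifluoromethyl)phenyl to 4-chlorophenyl now has a measured number at both ends (a 1.6-fold lower number from compound 3 to compound 4 (0.20 log units; within the scatter)), so on this core the two groups cannot be told apart. On the core of compound 1 the same change cannot be sized: the same change on two cores in this assay, an at least 1.1-fold lower number (0.05 log units; that floor lies within the scatter) from compound 1 to compound 2 and a 1.6-fold higher number (0.20 log units; within the scatter) from compound 4 to compound 3; the limit leaves it open whether they differ. Trifluoromethyl in place of methyl, by contrast, gives a clear drop here too (an at least 5.8-fold lower number from compound 1 to compound 4 (0.76 log units; beyond the scatter)), and it does so on both cores: the same change on two cores in this assay, a 3.3-fold lower number (0.51 log units; beyond the scatter) from compound 2 to compound 3 and an at least 5.8-fold lower number (0.76 log units; beyond the scatter) from compound 1 to compound 4; the limit leaves it open whether they differ.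

As far as these compounds go, what an amine or a carboxylic acid at this position would give remains open. So does the real number for compound 1, whose > 100000 nM is a limit.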